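Bromo for Methoxy on a Triazole-Linked Chalcone

The compounds below may be only part of what the source reports. "The series", "measured", "known", "first", "only" and "open" are said of these compounds alone.

Compound 1 `COc1cc(/C=C/C(=O)c2cccc(N=[N+]=[N-])c2)ccc1O` gives 7110 nM in a functional assay on RAW264.7 cells (Mus musculus) for inhibition, with a stated time of 4 days; a lower number here means a stronger inhibitor, a higher number a weaker inhibitor.
Compound 2 `COc1ccc(/C=C/C(=O)c2cccc(N=[N+]=[N-])c2)cc1O` gives 1960 nM.
Compound 3 `COc1ccc(-c2cn(-c3cccc(C(=O)/C=C/c4ccc(O)c(OC)c4)c3)nn2)cc1` gives 7900 nM.

In this assay compound 3 carries the highest of the three numbers, yet its gap to compound 1 lies within the usual scatter, so only compound 2 stands clearly apart from it. Compound 4 `COc1cc(/C=C/C(=O)c2cccc(-n3cc(-c4ccc(Br)cc4)nn3)c2)ccc1O` differs from compound 3 in a single place: bromo in place of methoxy on an aromatic carbon. Seen one bond further out, a 4-methoxyphenyl becomes a 4-bromophenyl. Among the measured compounds shown here, no measured pair here shows this swap, so nothing anchors a direction, and the step is expected to stay within the scatter: a 1.1-fold lower number from compound 3 to compound 4 (0.05 log units; within the scatter). Compound 4 is therefore estimated at about 7000 nM, with a range from 2500 nM to 20000 nM.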

Compound 4, half-maximal inhibitory concentration: 19100 nM
Compound 4: the middle estimate sits 2.7-fold (0.44 log units) below what was measured, and the stated range covers the measured number.
By their numbers in this assay, from the lowest: compound 2; then compounds 1 and 3 (each within the scatter of the next); then compound 4.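

In this assay, replacing the 4-methoxyphenyl with a 4-bromophenyl gives a 2.4-fold higher number from compound 3 to compound 4 (0.38 log units; beyond the scatter), so inhibition weakens modestly. Among the compounds shown here, this is the first measured one-place step, and it shows that the group at this position, para to a large group, can shift the number beyond the scatter. No measurement here gives a reason for this step.

Going by these compounds, whether a fluoro, a hydroxyl or an amine at the same place would strengthen or weaken inhibition remains open. So does whether the same swap would have a similar effect on a different core.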